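The source may report more compounds than this note shows. Statements on the series, on what has been measured and on what is new or still open speak of the compounds shown alone.

In a functional assay on A549 cells (Homo sapiens) for antiproliferative activity, read by MTT assay, with a stated time of 48 h (on this read-out higher numbers stand for weaker inhibition and lower numbers for stronger inhibition), compound 1 (`COc1ccc(N(C)c2ccnc(Cl)n2)cc1OCCCBr`) gives 862 nM, compound 2 (`COc1ccc(N(C)c2ccnc(Cl)n2)cc1OCCCCCBr`) gives 9720 nM and compound 3 (`COc1ccc(N(C)c2ccnc(Cl)n2)cc1OCC[Se]C#N`) gives 463 nM. Compound 3 stands level with compound 1 within the scatter (a 1.9-fold lower number from compound 1 to compound 3 (0.27 log units; within the scatter)) and well clear of compound 2 (a 21-fold lower number from compound 2 to compound 3 (1.32 log units; beyond the scatter)). The next structure is compound 4 (`COc1ccc(N(C)c2ccnc(Cl)n2)cc1OCCCCC[Se]C#N`), and the change is this: a group of 6 heavy atoms (4 carbon, 1 nitrogen, 1 selenium; no ring) in place of a group of 3 heavy atoms (1 carbon, 1 nitrogen, 1 selenium; no ring), on a saturated chain carbon, two bonds along the chain from an oxygen on an aromatic ring on an otherwise shared core. Within the data shown here, only one measured step shows a longer chain with the end group held constant (an 11-fold higher number from compound 1 to compound 2 (1.05 log units; beyond the scatter)), and it is large and beyond the scatter. Exchanging the end group at compound 1 (a 1.9-fold lower number from compound 1 to compound 3 (0.27 log units; within the scatter)) stayed within the scatter, which suggests that chain length may matter more here than the end group, though this rests on very few compounds. Compound 4 is therefore expected to show a higher number in this assay by a large step (a 6.0-fold higher number from compound 3 to compound 4 (0.78 log units; beyond the scatter)). Compound 4 is estimated at 2800 nM (expected range 700 nM to 10000 nM).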

Compound 4, half-maximal inhibitory concentration: > 10000 nM
Compound 4: no number, only a limit; the forecaster's own chance of this, stated with the estimate: 3%; middle value at least 3.5-fold (0.55 log units) from the limit.
By their numbers in this assay, from the lowest: compounds 3 and 1 (each within the scatter of the next); then compound 2. At a limit, above all of these: compound 4.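

In this assay compound 4 gives > 10000 nM, which is a limit and not a number. Lengthening the chain with the selenium and nitrile end group held constant brings a large step, an at least 21-fold higher number from compound 3 to compound 4 (1.33 log units; beyond the scatter), so the loss seen on lengthening the chain with a bromo end now appears with a second end group as well. Compound 4 also lies far from the shorter bromo compound, an at least 11-fold higher number from compound 1 to compound 4 (1.06 log units; beyond the scatter), whereas against the bromo compound of the same chain length, an at least 1.0-fold higher number from compound 2 to compound 4 (0.01 log units; that floor lies within the scatter), the floor allows no order to be read.

As far as these compounds go, how far past the limit compound 4 lies remains open. So does whether a chain of intermediate length, or an amine or a carboxylic acid at the chain end, would keep the lower numbers.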